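A Dichlorophenyl Swap Tested Against a Run of Limits

The compounds below may be only part of what the source reports. "The series", "measured", "known", "first", "only" and "open" are said of these compounds alone.

Compound 3 `O=C(NCCCN1CCN(c2ncccn2)CC1)c1ccc2ccccc2c1` stands on a limit rather than a number. In an assay on HEK293 cells for inhibition of sodium-dependent dopamine transporter (Homo sapiens), read by scintillation counting (a lower number here means a stronger inhibitor, a higher number a weaker inhibitor), compound 3 gives > 10000 nM, which is a limit of the assay. Compound 2 `O=C(NCCCN1CCN(c2ccccn2)CC1)c1ccc2ccccc2c1` gives > 10000 nM, also a limit. Compound 1 `O=C(NCCCN1CCN(c2cccc(Cl)c2Cl)CC1)c1cc(Cl)cc(Cl)c1` gives > 10000 nM, again a limit. The step that the two limits leave unreadable from compound 2 to compound 3 is thus unreadable in size. Compound 4 `O=C(NCCCN1CCN(c2cccc(Cl)c2Cl)CC1)c1ccc2ccccc2c1` differs from compound 3 by 2,3-dichlorophenyl in place of pyrimidin-2-yl on an amine nitrogen in a ring. For the measured compounds named here, no measured step bears directly on this change; what the three compounds show is the limit of > 10000 nM in this assay, at which 3 of the 3 values shown sit, and compound 1 already carries the same 2,3-dichlorophenyl group on its ring nitrogen while sitting at that limit. A step of an at least 1.2-fold lower number from compound 3 to compound 4 (0.09 log units; that floor lies within the scatter) is therefore expected, with compound 4 estimated at 8000 nM, between 2000 nM and 30000 nM, most likely once more only a limit.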

Compound 4, half-maximal inhibitory concentration: > 10000 nM
Compound 4: no number, only a limit (the forecaster's own chance of this, stated with the estimate: 60%); middle value at least 1.2-fold (0.09 log units) away from the limit.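

No new step can be read between compound 4 and compound 1, compound 2 or compound 3, since each value is only a limit: the limit of > 10000 nM in this assay, at which 4 of the 4 values shown sit.

The compounds shown leave open how strongly any of them acts in this assay.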